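The source may hold more compounds than are shown below. What is called first, only, known or untested is meant among the compounds shown, and "the series" means these compounds.

Compound 2 `Clc1ccc(CO/N=C/c2c(-c3ccccc3)nc3sccn23)cc1Cl` and compound 1 `Clc1ccc(CO/N=C/c2c(-c3ccc4ccccc4c3)nc3occn23)cc1Cl` share a core and a dichlorobenzyl oxime arm. In an assay on HepG2 cells for agonist activity at nuclear receptor subfamily 1 group I member 3 (Homo sapiens), read by a luciferase reporter, with a stated time of 23 h (on this read-out lower numbers stand for an effect already at smaller amounts and higher numbers for an effect only at larger amounts of compound), compound 1 gives 370 nM, while compound 2 gives 580 nM; compound 2 holds the highest of the two numbers, and its nearest neighbour is compound 1, whose value lies within the scatter of it. Compound 3 `Cc1ccc(-c2nc3sccn3c2/C=N/OCc2ccc(Cl)c(Cl)c2)cc1` differs from compound 2 by methyl in place of hydrogen on an aromatic carbon. Within the data shown here, no measured pair shows this change, so the expected step from compound 2 to compound 3 in this assay is a small one, a 1.5-fold lower number from compound 2 to compound 3 (0.16 log units; within the scatter), downward if anything. Compound 3 is therefore estimated at 400 nM, within a range from 150 nM to 1200 nM.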

Compound 3, half-maximal effective concentration: 490 nM
Estimate against measurement, compound 3: 1.2-fold (0.09 log units) below; measured number inside the range.
By their numbers in this assay, from the lowest: compounds 1, 3 and 2 (each within the scatter of the next).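

Methyl on this aromatic carbon, para to a large group, is the first single change that can be read here: in this assay it gives a 1.2-fold lower number from compound 2 to compound 3 (0.07 log units; within the scatter). Going from phenyl to 4-methylphenyl therefore brings neither a clear gain nor a clear loss at this place. No measurement at hand offers an explanation for this result. From the compounds shown here alone, whether an amine, a carboxylic acid or a longer chain at the same place would move the number beyond the scatter stays open.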